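A few compounds are considered here, and "the series" means these few. Any claim that something is new, unique, unknown or untested is made for them only; others in the source may bear on it.

Compound 1 `CC(C)(C)c1ccc(C(=O)N2CCC3(CC2)C(=O)N(CC(=O)NCCC(=O)O)CN3c2ccccc2)cc1` gives 11400 nM in an assay on HEK293 cells for displacement of a labelled ligand from NPC1-like intracellular cholesterol transporter 1 (Homo sapiens); a lower number here means a stronger inhibitor, a higher number a weaker inhibitor. Compound 2 `CC(C)(C)OC(=O)NC1CCCN(C(=O)CN2CN(c3ccccc3)C3(CCN(C(=O)c4ccc(C(C)(C)C)cc4)CC3)C2=O)C1` gives 4200 nM in this assay. Compound 3 `CC(C)(C)c1ccc(C(=O)N2CCC3(CC2)C(=O)N(CC(=O)N2CCCCC2CO)CN3c2ccccc2)cc1` gives 11800 nM in this assay.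

Among the three values, compound 3 carries the highest number, but its distance from compound 1 is only a 1.0-fold higher number from compound 1 to compound 3 (0.01 log units; within the scatter), a move within the usual scatter; compound 2 sits lower, and that gap does lie beyond the scatter. Compound 4 `CCOC(=O)C1CCCN(C(=O)CN2CN(c3ccccc3)C3(CCN(C(=O)c4ccc(C(C)(C)C)cc4)CC3)C2=O)C1` differs from compound 3 in a single place: 3-(ethoxycarbonyl)piperidin-1-yl in place of 2-(hydroxymethyl)piperidin-1-yl on a carbonyl carbon. Among the measured compounds shown here, the one measured step at this same carbonyl carbon, that from compound 1 to compound 3, produced no change beyond the scatter, so it gives no direction of its own. Compound 2 also carries a substituted piperidine on that carbonyl and shows a lower number than compound 3, though no single-step comparison between those two exists and only their two values can be read. Taking both together, a modest move toward a lower number is expected for compound 4, of about a 1.7-fold lower number from compound 3 to compound 4 (0.23 log units; within the scatter). The estimate for compound 4 in this assay is 7000 nM, with a range from 2500 nM to 20000 nM.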

Compound 4, half-maximal inhibitory concentration: 8200 nM
The estimate for compound 4 lay 1.2-fold (0.07 log units) below the measured number; low and high end bracket the measured number.
By their numbers in this assay, from the lowest: compounds 2, 4, 1 and 3 (each within the scatter of the next, the first and the last beyond it).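

At this carbonyl carbon, the new ester-bearing piperidine gives a 1.4-fold lower number from compound 3 to compound 4 (0.16 log units; within the scatter) in this assay, and a 1.4-fold lower number from compound 1 to compound 4 (0.14 log units; within the scatter), so neither swap shifts the number measurably, even though 3-(ethoxycarbonyl)piperidin-1-yl has more heavy atoms and no hydrogen-bond donor. On the saturated ring carbon, ethoxycarbonyl in place of (tert-butoxycarbonyl)amino gives a 2.0-fold higher number from compound 2 to compound 4 (0.29 log units; within the scatter), so every step to compound 4 stays within the scatter, although compound 2 at 4200 nM and compound 3 at 11800 nM remain further apart than that. No supporting measurement is available to explain these results.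

Going by these compounds, the effect of an unsubstituted piperidin-1-yl group remains open, so the contribution of the ring alone cannot be separated from that of its substituents. A primary amine or a carboxylic acid on the piperidine ring also remains untested among the compounds shown.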